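A few compounds are considered here, and "the series" means these few. Any claim that something is new, unique, unknown or untested is made for them only; others in the source may bear on it.

Compounds measured so far in an assay on tissue (HeLa cells) for inhibition of Indoleamine 2,3-dioxygenase 1 (Homo sapiens), read by spectrophotometry; on this read-out higher numbers stand for weaker inhibition and lower numbers for stronger inhibition:
Compound 1, `O/N=C(/Nc1cccc(Cl)c1)c1ccc2occc2c1`, gives 1500 nM.
Compound 2, `CC(=O)c1cccc(N/C(=N/O)c2ccc3occc3c2)c1`, gives only the limit of the assay, > 30000 nM.
Compound 3, `O=C(NCc1ccccc1)c1cccc(N/C(=N/O)c2ccc3occc3c2)c1`, gives only the limit of the assay, > 30000 nM.

The three share one core and differ only in the group on one aromatic carbon. Putting an acetyl there in place of the chloro of compound 1 produces an at least 20-fold higher number from compound 1 to compound 2 (1.30 log units; beyond the scatter), a clear loss of inhibition. Turning the methyl of that acetyl into a benzylamino gives a step that the two limits leave unreadable from compound 2 to compound 3, because both values are limits (the limit of > 30000 nM in this assay, at which 2 of the 3 values shown sit). For the measured compounds named here, compound 3 thus stands at the weak end of what has been seen: no number is known for it, only the limit, and the single real number in the set belongs to compound 1.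

Compound 4, `CC1CCN(C(=O)c2cccc(N/C(=N/O)c3ccc4occc4c3)c2)CC1`, carries the next change: 4-methylpiperidin-1-yl in place of benzylamino on a carbonyl carbon. Going by the values given here, both carbonyl-bearing compounds, compound 2 and compound 3, sit at the limit, and the only readable step, from chloro to acetyl, was large and toward weaker inhibition. Nothing measured separates one amide substituent from another. The expectation is therefore that compound 4 also shows no step beyond the scatter, a number no higher from compound 3 to compound 4 (the limit leaves the size open), and most likely again only a limit. Compound 4 is estimated at 30000 nM, within 8000 nM to 100000 nM.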

Compound 4, half-maximal inhibitory concentration: > 30000 nM
Compound 4 was reported as a limit; the forecaster's own chance of this, stated with the estimate: 70%; the middle value sits exactly at the limit.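

In this assay, putting (4-methylpiperidin-1-yl)carbonyl in place of the chloro gives an at least 20-fold higher number from compound 1 to compound 4 (1.30 log units; beyond the scatter), so the large loss first seen with acetyl also appears with a tertiary amide on this aromatic carbon. The steps among compound 2, compound 3 and compound 4 cannot be read, because all three end at the same limit: the limit of > 30000 nM in this assay, at which 3 of the 4 values shown sit. Even so, compound 4 adds something that compound 3 could not show: removing the hydrogen-bond donor of benzylamino and exchanging its aromatic ring for the non-aromatic ring of 4-methylpiperidin-1-yl does not bring inhibition back into the readable range.

As far as these compounds go, how much weaker these three compounds really are remains unknown, and so does whether their carbonyl substituents differ at all, since only real numbers could separate them. Also open, from the compounds shown here alone, is whether a group on that aromatic carbon without a carbonyl, such as fluoro, methyl or an amine, would keep inhibition close to that of compound 1, which gives 1500 nM.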